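The source may hold more compounds than are shown below. What is called first, only, known or untested is meant among the compounds shown, and "the series" means these compounds.

Working notes on the series. Compound 1 `Cc1cccc(C(=O)NN(C(=O)c2ccccc2Cl)C(C)(C)C)c1` and compound 2 `Cc1cccc(C(=O)NN(C(=O)c2ccccc2Cl)C(C)(C)C)c1C` share the same core and differ only at one aromatic carbon. In an assay on cells for agonist activity at ecdysone receptor (Bombyx mori), read by a luciferase reporter, with a stated time of 24 h (a higher number here means that more compound is needed for the effect, a lower number that less compound is needed), compound 1 gives 603 nM, and compound 2 gives 20 nM. For the measured compounds named here, the one measured step is a 30-fold lower number from compound 1 to compound 2 (1.48 log units; beyond the scatter), so compound 2 stands at the lower of the two numbers, with compound 1 as its only neighbour. Compound 3 `Cc1ccc(C(=O)NN(C(=O)c2ccccc2Cl)C(C)(C)C)c(C)c1` has not yet been measured in this assay; the change from compound 2 is 2,4-dimethylphenyl in place of 2,3-dimethylphenyl on a carbonyl carbon. Going by the values given here, no measured step bears directly on relocating one methyl within the same ring; the only step seen, a 30-fold lower number from compound 1 to compound 2 (1.48 log units; beyond the scatter), concerns adding a methyl, not moving it. The expectation is a modest rise in the number, a 3.0-fold higher number from compound 2 to compound 3 (0.48 log units; beyond the scatter), and compound 3 is estimated at 60 nM, within a range from 15 nM to 250 nM.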

Compound 3, half-maximal effective concentration: 162 nM
Estimate against measurement, compound 3: 2.7-fold (0.43 log units) below; the measured number falls inside the stated range.
By their numbers in this assay, from the lowest: compound 2; then compound 3; then compound 1.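

Relocating a single methyl within the same ring is enough to change the reading in this assay (an 8.1-fold higher number from compound 2 to compound 3 (0.91 log units; beyond the scatter)), so the number depends on the arrangement of the methyl groups and not only on their count, which the earlier pair could not show. The 2,4-dimethylphenyl group on the carbonyl carbon still reads lower than 3-methylphenyl (a 3.7-fold lower number from compound 1 to compound 3 (0.57 log units; beyond the scatter)), so a lower number than that of compound 1 is not confined to 2,3-dimethylphenyl. The data offer no explanation for the difference between the two dimethylphenyl groups.

The compounds shown leave open whether the number follows one methyl or the particular pair of methyl groups. As far as these compounds go, how an ethyl or a methoxy group on this ring would read also remains open.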